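A few compounds are considered here, and "the series" means these few. Any claim that something is new, unique, unknown or untested is made for them only; others in the source may bear on it.

Working notes on the series. Going by the values given here, in a functional assay on ileum (Cavia porcellus) for antagonist activity (a lower number here means a stronger inhibitor, a higher number a weaker inhibitor), compound 1 (`Cc1ccc(CCCCOc2ccc3c(O)c([N+](=O)[O-])c(=O)oc3c2)cc1`) gives 2500 nM and holds the higher of the two actual numbers so far. Compound 2 (`CCCc1c(OCCCOc2ccccc2)ccc2c(O)c([N+](=O)[O-])c(=O)oc12`) gives a lower number (540 nM), a gap beyond the usual scatter. Compound 3 (`COC(=O)c1ccc(OCCCOc2ccc3c(O)c([N+](=O)[O-])c(=O)oc3c2)cc1`) is reported only as a limit of the assay (> 10000 nM).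

The next compound for this assay is compound 4 (`N#Cc1ccc(OCCCOc2ccc3c(O)c([N+](=O)[O-])c(=O)oc3c2)cc1`). Against compound 1 it carries 4-cyanophenoxy in place of 4-methylbenzyl on a saturated chain carbon, three bonds along the chain from an oxygen on an aromatic ring. Among the compounds with values here, no measured pair isolates this change. In structure compound 4 stands closer to compound 3 than to compound 1, and the reading for compound 3 is a limit (> 10000 nM). A modest move toward a weaker number is therefore expected, and the estimated step is (a 2.4-fold higher number from compound 1 to compound 4 (0.38 log units; beyond the scatter)). For compound 4 the estimated value is 6000 nM (expected range 2000 nM to 15000 nM).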

Compound 4, half-maximal inhibitory concentration: > 10000 nM
Compound 4 gave a limit, no number; the forecaster's own chance of this, stated with the estimate: 35%; at least 1.6-fold (0.22 log units) between middle value and limit.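

In this assay compound 4 stands only as a limit of the assay, > 10000 nM. Even so, 4-cyanophenoxy in place of 4-methylbenzyl on a saturated chain carbon, three bonds along the chain from an oxygen on an aromatic ring, gives the first readable step at this position: an at least 4.0-fold higher number from compound 1 to compound 4 (0.60 log units; beyond the scatter), beyond the scatter. Cyano in place of methoxycarbonyl on an aromatic carbon leaves the reading at the limit, so the step between compound 3 and compound 4 cannot be read, and the limit now recurs in the series: the limit of > 10000 nM in this assay, at which 2 of the 4 values shown sit.

Which part of the exchange in compound 4 carries the step stays open, since 4-cyanophenoxy and 4-methylbenzyl differ in more than one feature. Also open, on these data alone, is whether an amine or a carboxylic acid in place of cyano would return a number rather than a limit.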